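The compounds below may be only part of what the source reports. "The series", "measured", "known", "first", "only" and "open" are said of these compounds alone.

In a functional assay on U-251 cells (Homo sapiens) for cytotoxicity (a higher number here means a weaker inhibitor of growth, a lower number a stronger inhibitor of growth), compound 1 `COc1ccc(C2=C(c3cc(OC)c(OC)c(OC)c3)CC3CCCN3C2=O)cc1O` gives > 100000 nM, which is a limit of the assay and not a number. Going by the values given here, compound 2 `CSc1ccc(C2=C(c3ccc(O)c(O)c3)C(=O)N3CCCC3C2)cc1` gives 30000 nM, the only actual number so far, so it serves as the sole reference point. Compound 3 `CSc1ccc(C2=C(c3ccc(C)cc3)C(=O)N3CCCC3C2)cc1` has 4-methylphenyl in place of 3,4-dihydroxyphenyl on a double-bonded ring carbon, next to the ring atom that bears a 4-(methylsulfanyl)phenyl group (4-methylphenyl in place of 3,4-dihydroxyphenyl on a double-bonded ring carbon). Among the compounds with values here, no measured pair differs in one place only, so the data give no direct size for this step in this assay. The change removes both hydroxyl-bearing positions of the dihydroxyphenyl group, and the direction of its effect cannot be read from the measurements. The expected outcome is therefore no step beyond the scatter, with a slight lean towards weaker growth inhibition, and the estimated step is a 1.3-fold higher number from compound 2 to compound 3 (0.12 log units; within the scatter). This expectation rests on compound 2 at 30000 nM alone, so the range is kept wide. For compound 3 the estimated value is 40000 nM, with an expected range of 10000 nM to 100000 nM.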

Compound 3, concentration for 50% growth inhibition: 400 nM
For compound 3 the middle estimate is 100-fold (2.00 log units) above the measured one; measured number below the stated range.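

In this assay, 4-methylphenyl in place of 3,4-dihydroxyphenyl on the double-bonded ring carbon gives a 75-fold lower number from compound 2 to compound 3 (1.88 log units; beyond the scatter), so growth inhibition here depends strongly on the group at this position. The 4-(methylsulfanyl)phenyl group and the rest of the shared core stay the same in this pair, which ties the step to this single exchange, although the exchange removes the hydroxyl groups and adds a methyl group together, and one pair cannot separate the two. Compound 1 gives only a limit and not a number, and it differs from compound 2 in more than one place, so it adds no readable step: the limit of > 100000 nM in this assay, at which 1 of the 3 values shown sits.

On these data alone, it remains open whether the step comes from losing the hydroxyl groups or from gaining the methyl group; an unsubstituted phenyl and a 4-hydroxyphenyl at this position would help to separate the two. Also open, as far as these compounds go, are how a carboxylic acid or an amine on this ring would compare, and whether the step holds with another group in place of 4-(methylsulfanyl)phenyl.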